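Swapping Trifluoromethyl for Methyl: Clearance in Rat Liver Cells

The source may report more compounds than this note shows. Statements on the series, on what has been measured and on what is new or still open speak of the compounds shown alone.

Compound 1 `CS(=O)(=O)c1cnc(Nc2ccc(O)cc2)nc1NCc1ccccc1`: 32 uL/min
Compound 2 `CN(Cc1ccc2nccn2c1)c1nnc(-c2ccc(OC3CCCC3)cc2)o1`: 52 uL/min
Compound 3 `CNC(=O)c1sc(N2CC3CC2(CNC(=O)c2c[nH]c4ncc(C(F)(F)F)cc24)C3)nc1C(F)(F)F`: 78 uL/min

Of the compounds shown here, three have been measured in an ADME assay on cells (Hepatocyte, Rattus norvegicus) for metabolic stability; a lower number here means slower removal, a higher number faster removal of the compound. Compound 1 gives 32 uL/min, compound 2 gives 52 uL/min and compound 3 gives 78 uL/min. Compound 3 carries the highest number of the three; its value and that of compound 2 lie within the scatter of each other, while compound 1 sits beyond the scatter with the lower number.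

Compound 4 `CNC(=O)c1sc(N2CC3CC2(CNC(=O)c2c[nH]c4ncc(C)cc24)C3)nc1C(F)(F)F` differs from compound 3 in one place: methyl in place of trifluoromethyl on an aromatic carbon. Among the compounds with values here, no pair of measured compounds shows this change, so no measured step exists to lean on. The expected step is a 1.2-fold higher number from compound 3 to compound 4 (0.09 log units; within the scatter), a modest rise that stays within the scatter. Compound 4 is therefore estimated at 95 uL/min, with a range from 45 uL/min to 200 uL/min.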

Compound 4, intrinsic clearance in a liver preparation (reported as CLH), per the amount of preparation that the assay uses in the Hepatocyte assay: 92 uL/min
Compound 4: the middle estimate sits 1.0-fold (0.01 log units) above what was measured; low and high end bracket the measured number.
By their numbers in the Hepatocyte assay, from the lowest: compounds 1, 2, 3 and 4 (each within the scatter of the next, the first and the last beyond it).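

In the Hepatocyte assay, methyl in place of trifluoromethyl on this aromatic carbon, two atoms from the ring nitrogen, gives a 1.2-fold higher number from compound 3 to compound 4 (0.07 log units; within the scatter) and so shows no clear shift in clearance for this change. In a physicochemical assay for solubility (a higher number here means a more soluble compound, a lower number a less soluble compound), compound 3 gives < 1600 nM as a limit of the assay. In the physicochemical assay compound 4 gives < 1600 nM as a limit too, so the step between the two cannot be read.

On these data alone, whether a chlorine atom or an amine on this carbon would shift clearance beyond the scatter remains open. Solubility also remains open, with both values stopping at one limit: the limit of < 1600 nM in the physicochemical assay, at which 2 of the 2 values shown sit.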